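This account rests on a few compounds, and the source may have more. Where it says the series, first, only, none or still open, it means among the compounds named here.

Compound 2 `C=C[C@@](C)(/C=C/c1ccc(Nc2ccc(F)cc2)cc1)CCC=C(C)C` stands at > 52000 nM in a functional assay on HepG2 cells (Homo sapiens) for cytotoxicity, with a stated time of 72 h (a lower number here means that less compound is needed, a higher number that more compound is needed for the effect), which is a limit of the assay rather than a number. Compound 1 `C=C[C@@](C)(/C=C/c1ccc(OS(=O)(=O)C(F)(F)F)cc1)CCC=C(C)C` likewise gives a limit in this assay, > 52000 nM. The step that the two limits leave unreadable from compound 1 to compound 2 is therefore unreadable. Compound 3 `C=C[C@@](C)(/C=C/c1ccc(Nc2c(F)cc(F)cc2F)cc1)CCC=C(C)C` differs from compound 2 in one place: 2,4,6-trifluorophenyl in place of 4-fluorophenyl on a nitrogen on an aromatic ring. Within the data shown here, no readable step bears on this change; the only evidence is the limit of > 52000 nM in this assay, at which 2 of the 2 values shown sit. Compound 3 is thus expected to give a limit again, with a step that the limit leaves unreadable from compound 2 to compound 3 as a step of no readable size. The estimated value of compound 3 is 80000 nM, ranging from 30000 nM to 300000 nM.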

Compound 3, half-maximal effective concentration: > 52000 nM
Compound 3: no number, only a limit; the forecaster's own chance of this, stated with the estimate: 85%; the middle value lies beyond the limit too.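

Among these compounds, compound 2 and compound 3 both give only a limit in this assay, so no step between them can be read. The compounds shown leave open whether 2,4,6-trifluorophenyl in place of 4-fluorophenyl changes the half-maximal effective concentration at all.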